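Undoing part of a lengthened side chain

This account rests on a few compounds, and the source may have more. Where it says the series, first, only, none or still open, it means among the compounds named here.

Among the measured compounds shown here, compound 2 `Nc1nc(O)c2c(n1)n(C1OC(CO)[C@@H](O)[C@H]1O)c(=O)n2CCN1CCCCC1` stands at the bottom of the two numbers measured so far: in a functional assay on the whole organism with Mus musculus as the target (a higher number here means a larger maximal response, a lower number a smaller maximal response), compound 2 gives 0%. For the measured compounds named here, compound 1 `Cn1c(=O)n(C2OC(CO)[C@@H](O)[C@H]2O)c2nc(N)nc(O)c21` is its only measured neighbour, and in this assay compound 1 gives 100%. Going by the values given here, the single recorded step runs the other way, a number 100 percentage points lower from compound 1 to compound 2 (beyond the scatter), where (piperidin-1-yl)methyl replaced hydrogen on a saturated chain carbon bound to an aromatic nitrogen. Compound 3 `CCCCn1c(=O)n(C2OC(CO)[C@@H](O)[C@H]2O)c2nc(N)nc(O)c21` reverses only part of that: ethyl in place of piperidin-1-yl on a saturated chain carbon, two bonds along the chain from an aromatic nitrogen. The ring leaves, but the chain stays longer than in compound 1. Because the entire loss a number 100 percentage points lower from compound 1 to compound 2 (beyond the scatter) came with the added (piperidin-1-yl)methyl, removing the ring is expected to recover some response, though the longer chain leaves this uncertain, and the expected step is a number 50 percentage points higher from compound 2 to compound 3 (beyond the scatter). Compound 3 is estimated at 50%, with a range from 5% to 100%.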

Compound 3, largest response reached (reported as maximal response), in percent of the reference or control that the assay uses: 70%
The estimate for compound 3 lay 20 percentage points below the measured number; the measured number falls inside the stated range.
By their numbers in this assay, from the lowest: compound 2; then compound 3; then compound 1.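

Putting ethyl in place of piperidin-1-yl, on a saturated chain carbon two bonds along the chain from an aromatic nitrogen, gives a number 70 percentage points higher from compound 2 to compound 3 (beyond the scatter) in this assay and so restores most of the lost response. A chain of this length still leaves a clear response, so the piperidin-1-yl ring, rather than the lengthening, accounts for most of the drop. Lengthening has its own cost, however: propyl in place of hydrogen on a saturated chain carbon bound to an aromatic nitrogen gives a number 30 percentage points lower from compound 1 to compound 3 (beyond the scatter) and this smaller step belongs to the longer chain alone.

As far as these compounds go, it remains open whether the response keeps falling with a longer chain such as hexyl, and whether a cyclohexyl ring or an open dimethylamino group at the chain end would match piperidin-1-yl. Nothing available gives a reason for either step.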